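Cyclopentyl Amide Variant of a Quinoline Amide Series

The source may hold more compounds than are shown below. What is called first, only, known or untested is meant among the compounds shown, and "the series" means these compounds.

Compound 1 `COc1cc2nccc(Oc3ccc(Nc4nn(C)cc4C(=O)N4CCCCC4)cc3)c2cc1C(N)=O`: 5650 nM
Compound 2 `COc1cc2nccc(Oc3ccc(Nc4nn(C)cc4C(=O)NC4CCCCCCC4)cc3)c2cc1C(N)=O`: 3210 nM
Compound 3 `COc1cc2nccc(Oc3ccc(Nc4nn(C)cc4C(=O)Nc4cccc(F)c4)cc3)c2cc1C(N)=O`: 4480 nM

In a functional assay on BaF3 cells (Mus musculus) for antiproliferative activity, read by CCK-8 assay and cell counting, with a stated time of 76 h (a lower number here means a stronger inhibitor, a higher number a weaker inhibitor), compound 1 gives 5650 nM, the largest of the three numbers, yet its steps to the other two lie within the scatter. Compound 4 `COc1cc2nccc(Oc3ccc(Nc4nn(C)cc4C(=O)NC4CCCC4)cc3)c2cc1C(N)=O` differs from compound 1 by cyclopentylamino in place of piperidin-1-yl on a carbonyl carbon. Among the measured compounds shown here, two measured steps bear on it: a 1.8-fold lower number from compound 1 to compound 2 (0.25 log units; within the scatter) and a 1.3-fold lower number from compound 1 to compound 3 (0.10 log units; within the scatter), both of which also replace the piperidin-1-yl with an amino-linked group, and both within the scatter. Between the two amino-linked compounds, a 1.4-fold higher number from compound 2 to compound 3 (0.14 log units; within the scatter). For the measured compounds named here, no measured step here moves beyond the scatter, so no step beyond the scatter is expected for compound 4, with at most a slightly lower number. Compound 4 is therefore estimated at 4000 nM, within 1800 nM to 9000 nM, meaning an expected 1.4-fold lower number from compound 1 to compound 4 (0.15 log units; within the scatter).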

Compound 4, half-maximal inhibitory concentration: > 10000 nM
Compound 4: only a limit was reported; the forecaster's own chance of this, stated with the estimate: 3%; middle value at least 2.5-fold (0.39 log units) away from the limit.
By their numbers in this assay, from the lowest: compounds 2, 3 and 1 (each within the scatter of the next). At a limit, above all of these: compound 4.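

In this assay compound 4 gives only a limit, > 10000 nM. On the amide-type nitrogen, cyclopentyl in place of cyclooctyl gives an at least 3.1-fold higher number from compound 2 to compound 4 (0.49 log units; beyond the scatter), and cyclopentyl in place of 3-fluorophenyl gives an at least 2.2-fold higher number from compound 3 to compound 4 (0.34 log units; beyond the scatter), so the group here can move the number beyond the scatter, which the earlier three compounds never showed. Against piperidin-1-yl the result is less firm: the change gives an at least 1.7-fold higher number from compound 1 to compound 4 (0.24 log units; that floor lies within the scatter). As far as these compounds go, whether cyclohexyl on this nitrogen would track cyclopentyl or cyclooctyl stays open. So does how far the number of compound 4 lies past its limit.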